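Moving the ring nitrogen in a cytotoxicity series

The compounds below may be only part of what the source reports. "The series", "measured", "known", "first", "only" and "open" are said of these compounds alone.

Of the compounds shown here, three with a shared core have been tested in an ADME assay on HEK293 cells (Homo sapiens) for cytotoxicity, read by CCK-8 assay and cell counting, with a stated time of 2 days; a higher number here means a weaker inhibitor, a lower number a stronger inhibitor. Compound 1 `Oc1ccc(-c2cc(-c3ccc(Cl)cc3)nc(-c3cccnc3)c2)cc1` gives 27500 nM, the second highest of the three numbers. Compound 2 `Oc1cccc(-c2cc(-c3ccc(Cl)cc3)nc(-c3cccnc3)c2)c1` gives 39500 nM, and the change a 1.4-fold higher number from compound 1 to compound 2 (0.16 log units; within the scatter). Compound 3 `Oc1cccc(-c2cc(-c3ccc(Cl)cc3)nc(-c3ccsc3)c2)c1` gives 11200 nM; here the change a 3.5-fold lower number from compound 2 to compound 3 (0.55 log units; beyond the scatter).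

Compound 4 `Oc1ccc(-c2cc(-c3ccc(Cl)cc3)nc(-c3ccccn3)c2)cc1` has not yet been measured. It differs from compound 1 in one place: pyridin-2-yl in place of pyridin-3-yl on an aromatic carbon. Among the compounds with values here, no measured pair shows this exact change. The step from compound 2 to compound 3 does touch the same position on the core, but it swaps the group for a different one, and it was only modest. The step from compound 1 to compound 2 shows that a change elsewhere on the core stayed within the scatter. On that basis, compound 4 is expected to land close to compound 1, with a step of a 1.1-fold lower number from compound 1 to compound 4 (0.04 log units; within the scatter) that is expected to stay within the scatter. The estimate for compound 4 in this assay is 25000 nM, with a range from 10000 nM to 60000 nM.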

Compound 4, half-maximal inhibitory concentration: 27200 nM
For compound 4 the middle estimate is 1.1-fold (0.04 log units) below the measured one, and the stated range covers the measured number.
By their numbers in this assay, from the lowest: compound 3; then compounds 4, 1 and 2 (each within the scatter of the next).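

Swapping pyridin-3-yl for pyridin-2-yl gives no real shift (a 1.0-fold lower number from compound 1 to compound 4 (0.00 log units; within the scatter)), so in this assay the place of the nitrogen within this pyridine ring makes no difference for this pair. The earlier step at this position (a 3.5-fold lower number from compound 2 to compound 3 (0.55 log units; beyond the scatter)) replaced the pyridine with a thiophene, so the only shift beyond the scatter seen here comes with a change of ring, not with a move of the nitrogen within the same ring. Nothing available explains why this move leaves the number unchanged.

Going by these compounds, it remains open whether pyridin-4-yl, or a simple amine or carboxylic acid at this position, would also leave the number in place. On these data alone, it is equally open whether the same swap would hold on the core of compound 2, which carries 3-hydroxyphenyl instead of 4-hydroxyphenyl.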